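Moving the fluorine: 2-fluorophenyl to 4-fluorophenyl

A few compounds are considered here, and "the series" means these few. Any claim that something is new, unique, unknown or untested is made for them only; others in the source may bear on it.

Compound 1 `Oc1nc(-c2cccc(F)c2)nc2ccccc12` gives > 20 ug/mL in a functional assay on MCF7 cells (Breast, Homo sapiens) (a higher number here means that more compound is needed for the effect, a lower number that less compound is needed), which is a limit of the assay and not a number. Within the data shown here, compound 2 `COc1cc2nc(-c3ccccc3F)nc(O)c2cc1OC` gives 13.1 ug/mL in this assay and therefore holds the only actual number so far.

Compound 3 `COc1cc2nc(-c3ccc(F)cc3)nc(O)c2cc1OC` has the same atoms as compound 2, joined differently: 4-fluorophenyl in place of 2-fluorophenyl on an aromatic carbon. It carries 4-fluorophenyl in place of 2-fluorophenyl on an aromatic carbon, between two ring nitrogen atoms.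

Among the measured compounds shown here, no measured pair shows what this change does in this assay, so the expectation can only be anchored on compound 2 at 13.1 ug/mL. No shift beyond the scatter is expected, and the expected step is a 1.1-fold higher number from compound 2 to compound 3 (0.03 log units; within the scatter). A result for compound 3 at the limit of > 20 ug/mL in this assay, at which 1 of the 2 values shown sits, is also possible and would not be a surprise. For compound 3 the estimate is 14 ug/mL, with an expected range from 6 ug/mL to 20 ug/mL.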

Compound 3, concentration for half-maximal effect: 19.8 ug/mL
For compound 3 the middle estimate is 1.4-fold (0.15 log units) below the measured one; measured number inside the range.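

In this assay, among these compounds, the one step now readable at this position is a 1.5-fold higher number from compound 2 to compound 3 (0.18 log units; within the scatter), so 4-fluorophenyl in place of 2-fluorophenyl on the aromatic carbon between two ring nitrogen atoms gives no shift that can be told apart from repeat measurements. For this pair, the place of the fluorine on the phenyl ring has no readable effect on the number, and neither compound 2 nor compound 3 can be ranked over the other. Compound 1 differs from both in more than one place, which leaves it outside any comparison here, and its entry is a limit of the assay and not a number: the limit of > 20 ug/mL in this assay, at which 1 of the 3 values shown sits.

Still open, going by these compounds, is whether anything other than a fluorophenyl at this position, such as a phenyl ring carrying an amine or a carboxylic acid, or a longer alkyl chain in place of the ring, would move the number beyond the scatter. The contribution of the two methoxy groups on the shared core also stays open, since no pair shown differs in that place alone.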